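Swapping 3-hydroxypropyl for methylsulfonyl in compound 4

The compounds below may be only part of what the source reports. "The series", "measured", "known", "first", "only" and "open" are said of these compounds alone.

In an ADME assay on MRC5 cells (Homo sapiens) for cytotoxicity, read by fluorescence and resazurin assay, with a stated time of 3 days (on this read-out higher numbers stand for an effect only at larger amounts of compound and lower numbers for an effect already at smaller amounts), compound 3 (`O=C1C=CC(O)(c2cc3ccccc3n2S(=O)(=O)c2ccc(CCCO)cc2)C=C1`) gives 51 nM while compound 1 (`CCOC(=O)Nc1ccc(S(=O)(=O)n2c(C3(O)C=CC(=O)C=C3)cc3ccccc32)cc1`) gives 86 nM, and the two stand together, as a 1.7-fold lower number from compound 1 to compound 3 (0.23 log units; within the scatter) shows. Compound 2 (`COC(=O)CCc1ccc(S(=O)(=O)n2c(C3(O)C=CC(=O)C=C3)cc3ccccc32)cc1`) gives 280 nM and lies apart, as a 5.5-fold lower number from compound 2 to compound 3 (0.74 log units; beyond the scatter) shows. Compound 4 (`CS(=O)(=O)c1ccc(S(=O)(=O)n2c(C3(O)C=CC(=O)C=C3)cc3ccccc32)cc1`) has methylsulfonyl in place of 3-hydroxypropyl on an aromatic carbon, para to a large group (methylsulfonyl in place of 3-hydroxypropyl on an aromatic carbon). For the measured compounds named here, no measured compound carries methylsulfonyl, so the closest guide is the swaps at this same place, where a 3.3-fold higher number from compound 1 to compound 2 (0.51 log units; beyond the scatter) and a 5.5-fold lower number from compound 2 to compound 3 (0.74 log units; beyond the scatter) stayed modest. These swaps show that a change here can raise the number. In this assay a modest rise is therefore expected, estimated as a 2.2-fold higher number from compound 3 to compound 4 (0.33 log units; beyond the scatter) at this step. For compound 4 the estimated value is 110 nM with 35 nM to 350 nM as the expected range.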

Compound 4, half-maximal effective concentration: 39 nM
The estimate for compound 4 lay 2.8-fold (0.45 log units) above the measured number; measured number inside the range.
By their numbers in this assay, from the lowest: compounds 4, 3 and 1 (each within the scatter of the next, the first and the last beyond it); then compound 2.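

In this assay methylsulfonyl stands level with 3-hydroxypropyl, as a 1.3-fold lower number from compound 3 to compound 4 (0.12 log units; within the scatter) shows, so at this place the number holds with 0 hydrogen-bond donors in the group. Compound 4 also clears both other compounds, with a 7.2-fold lower number from compound 2 to compound 4 (0.86 log units; beyond the scatter) and with a 2.2-fold lower number from compound 1 to compound 4 (0.34 log units; beyond the scatter) as a separation beyond the scatter, which compound 3 did not reach from compound 1. No measured evidence accounts for these steps. As far as these compounds go, whether an amine, a carboxylic acid or a longer chain on this aromatic carbon would keep the number this low stays open.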